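The source may hold more compounds than are shown below. What is called first, only, known or untested is meant among the compounds shown, and "the series" means these compounds.

Among the compounds with values here, in an assay on HEK293 cells for displacement of a labelled ligand from Melanocortin receptor 4 (Homo sapiens) (on this read-out higher numbers stand for weaker inhibition and lower numbers for stronger inhibition), three compounds have numbers so far. Compound 1 `CC[C@H](C)C(N)c1cc(C(F)(F)F)ccc1N1CCN(C(=O)CCc2ccc(Cl)cc2Cl)CC1` gives 75 nM. Compound 2 `CCC(C)C(N)c1cc(C(F)(F)F)ccc1N1CCN(C(=O)CCc2ccc(Cl)cc2Cl)CC1` gives 160 nM, and the step of a 2.1-fold higher number from compound 1 to compound 2 (0.33 log units; beyond the scatter) rests on (the fact that one of compounds 1 and 2 is drawn with a defined configuration and the other without, at the place where they differ). Compound 3 `CCC(C)[C@H](N)c1cc(C(F)(F)F)ccc1N1CCN(C(=O)CCc2ccc(Cl)cc2)CC1` gives 86 nM in this assay; its number stands second highest of the three, yet it lies within the scatter of both compound 1 and compound 2.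

Compound 4 `CCC(C)[C@H](N)c1cc(C(F)(F)F)ccc1N1CCN(C(=O)CCc2ccc(OC)cc2Cl)CC1` differs from compound 3 by 2-chloro-4-methoxyphenyl in place of 4-chlorophenyl on a saturated chain carbon, two bonds along the chain from a carbonyl carbon. Within the data shown here, no measured step bears on this part of the molecule: the single measured step concerns a stereocentre on the saturated chain carbon carrying the amine, and compound 1 and compound 3 differ in two places at once, so their two values show only that they lie close together. Without a measured step touching the aromatic ring at the end of the chain, no shift beyond the scatter is expected in this assay, and the estimate is kept wide. Compound 4 is expected to give 100 nM, between 35 nM and 300 nM. The step of a 1.2-fold higher number from compound 3 to compound 4 (0.07 log units; within the scatter) is expected to stay within the scatter.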

Compound 4, inhibition constant: 57 nM
The estimate for compound 4 lay 1.8-fold (0.24 log units) above the measured number; the measured number falls inside the stated range.
By their numbers in this assay, from the lowest: compounds 4, 1, 3 and 2 (each within the scatter of the next, the first and the last beyond it).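

The aromatic ring at the end of the chain now has its first measured step: in this assay, 2-chloro-4-methoxyphenyl in place of 4-chlorophenyl gives a 1.5-fold lower number from compound 3 to compound 4 (0.18 log units; within the scatter). This place on the chain therefore carries the larger group, with its hydrogen-bond acceptor, and the number does not move by more than repeat measurements would. The evidence at hand concerns only a drawn stereocentre and does not bear on this ring change.

This step swaps the ring substitution in two ways at once, so the separate contributions of the added chlorine and of the methoxy in place of the 4-chloro group cannot be told apart. As far as these compounds go, it also remains open whether a more different group on this ring, such as a carboxylic acid or an amine in place of the methoxy, would shift the number beyond the scatter.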